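Swapping an Amine-Linked Ring for a Fluorinated Aryl Ether

The source may hold more compounds than are shown below. What is called first, only, known or untested is meant among the compounds shown, and "the series" means these compounds.

Compound 1 `Cc1cc(-c2cnn3c(NCC4CCOCC4)nc(NC4CCOCC4)nc23)ccc1C(=O)NC1CC1` is the stronger of the two compounds with a number in a functional assay on MDA-MB-231 cells (Homo sapiens) for antiproliferative activity (a lower number here means a stronger inhibitor of growth, a higher number a weaker inhibitor of growth), where compound 1 gives 540 nM. Compound 3 `O=C(NC1CC1)c1ccc(-c2cnn3c(NCC4CCOCC4)nc(NC4CCCC4)nc23)cc1F` gives 1400 nM in this assay, a weaker result that lies beyond the usual scatter. For compound 2 `CC(C)NC(=O)c1ccc(-c2cnn3c(NCC4CCOCC4)nc(OC4CCCC4)nc23)cc1` the result in this assay is "not determined" (no result reported). Compound 4 `Cc1cc(-c2cnn3c(NCC4CCOCC4)nc(Oc4cccc(F)c4F)nc23)ccc1C(=O)NC1CC1` differs from compound 1 in a single place: 2,3-difluorophenoxy in place of (oxan-4-yl)amino on an aromatic carbon. Within the data shown here, no measured pair shows this kind of change, so its effect remains open; the (oxan-4-yl)amino group is the only one of its kind here. A moderate loss of potency is expected, with a wide range around it. Compound 4 is estimated at 1500 nM, between 300 nM and 8000 nM. That estimate means an expected 2.8-fold higher number from compound 1 to compound 4 (0.44 log units; beyond the scatter).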

Compound 4, concentration for 50% growth inhibition: 12 nM
The estimate for compound 4 lay 130-fold (2.10 log units) above the measured number; measured number outside the range, below it.
By their numbers in this assay, from the lowest: compound 4; then compound 1; then compound 3.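

At this aromatic carbon between two ring nitrogen atoms, the change to 2,3-difluorophenoxy gives in this assay the step of a 45-fold lower number from compound 1 to compound 4 (1.65 log units; beyond the scatter) and so brings a large gain. The position therefore tolerates an aromatic ether, and the (oxan-4-yl)amino group and its hydrogen-bond donor are not required for activity in compound 4. Nothing available here explains the gain. A plain phenoxy group would show whether the two fluorines matter. A phenylamino group at the same carbon would show whether the ether oxygen matters.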